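A thiazole carbonyl in place of the nitrophenyl carbonyl

This account rests on a few compounds, and the source may have more. Where it says the series, first, only, none or still open, it means among the compounds named here.

Three measured compounds share one core and differ only in the group on the carbonyl carbon of the second amide. In an assay on isolated protein for inhibition of Rho-associated protein kinase 2 (Homo sapiens), read by scintillation counting, radiometric assay and 33P incorporation, with a stated time of 40 min, in the presence of a further agent that is not named here (a higher number here means a weaker inhibitor, a lower number a stronger inhibitor), compound 1 `O=C(COc1ccc2c(=O)ccoc2c1)Nc1cccc(NC(=O)c2ccccc2)c1` gives 16 nM. In this assay compound 2 `CCCc1ccc(C(=O)Nc2cccc(NC(=O)COc3ccc4c(=O)ccoc4c3)c2)cc1` gives 14 nM, and a 1.1-fold lower number from compound 1 to compound 2 (0.06 log units; within the scatter). In this assay compound 3 `O=C(COc1ccc2c(=O)ccoc2c1)Nc1cccc(NC(=O)c2cccc([N+](=O)[O-])c2)c1` gives 41 nM, the highest of the three numbers: a 2.6-fold higher number from compound 1 to compound 3 (0.41 log units; beyond the scatter), and a 2.9-fold higher number from compound 2 to compound 3 (0.47 log units; beyond the scatter).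

Compound 4 `Cc1nc(C(=O)Nc2cccc(NC(=O)COc3ccc4c(=O)ccoc4c3)c2)cs1` differs from compound 3 in one place: 2-methyl-1,3-thiazol-4-yl in place of 3-nitrophenyl on a carbonyl carbon. Among the compounds with values here, no measured step replaces the whole aryl group with a five-membered ring, so the steps that bear on this change are the two ending at compound 3, where the nitro group on the phenyl ring was the only feature that raised the number, namely a 2.6-fold higher number from compound 1 to compound 3 (0.41 log units; beyond the scatter) and a 2.9-fold higher number from compound 2 to compound 3 (0.47 log units; beyond the scatter). Taking that nitrophenyl away is therefore expected to bring the number back toward those of compound 1 and compound 2, with the step of a 1.6-fold lower number from compound 3 to compound 4 (0.21 log units; within the scatter) expected to be modest at most. For compound 4 the estimate in this assay is 25 nM, with a range from 8 nM to 80 nM.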

Compound 4, half-maximal inhibitory concentration: 33 nM
Estimate against measurement, compound 4: 1.3-fold (0.12 log units) below; the range from low to high includes it.
By their numbers in this assay, from the lowest: compounds 2 and 1 (each within the scatter of the next); then compounds 4 and 3 (each within the scatter of the next).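

In this assay, the 2-methyl-1,3-thiazol-4-yl group stands level with the 3-nitrophenyl group, a 1.2-fold lower number from compound 3 to compound 4 (0.09 log units; within the scatter), so a five-membered aromatic ring with no nitro group reads the same as the nitro-bearing ring at this carbonyl carbon. Removing the nitro group in this way does not return the number to those of the phenyl and 4-propylphenyl compounds: there is a 2.1-fold higher number from compound 1 to compound 4 (0.31 log units; beyond the scatter), and a 2.4-fold higher number from compound 2 to compound 4 (0.37 log units; beyond the scatter), both modest, so the higher numbers are not confined to the nitro compound. Nothing shown here gives a reason for these steps.

From the compounds shown here alone, what the methyl on the 2-methyl-1,3-thiazol-4-yl group contributes remains open. So does how a pyridine ring, or a phenyl ring carrying an amine or a carboxylic acid, would read on this carbonyl carbon in this assay.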